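Flavanone series: cytotoxicity limits and a methoxy addition

The source may report more compounds than this note shows. Statements on the series, on what has been measured and on what is new or still open speak of the compounds shown alone.

Measured so far:
Compound 1 `COc1ccc([C@@H]2CC(=O)c3c(O)c(C)c(O)c(C)c3O2)cc1` gives > 100000 nM in an ADME assay on MDCK cells (Canis lupus familiaris) for cytotoxicity, read by MTT assay, with a stated time of 2 days; a lower number here means that less compound is tolerated, a higher number that more compound is tolerated; this is a limit of the assay, not a number.
Compound 2 `Cc1c(O)c(C)c2c(c1O)C(=O)C[C@@H](c1ccccc1O)O2` gives > 100000 nM in this assay; this too is an assay limit.

Compound 2 thus stands at the limit of > 100000 nM in this assay, at which 2 of the 2 values shown sit, with no numerical value to rank it. Compound 3 `COc1ccc(O)c([C@@H]2CC(=O)c3c(O)c(C)c(O)c(C)c3O2)c1` differs from compound 2 by methoxy in place of hydrogen on an aromatic carbon. Among the measured compounds shown here, no measured step separates compounds in this set, so the expected step is none beyond the scatter, estimated as a step that the limit leaves unreadable from compound 2 to compound 3. Compound 3 is therefore expected at 150000 nM, with a range from 60000 nM to 400000 nM, most likely reported again as a limit.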

Compound 3, half-maximal cytotoxic concentration: > 100000 nM
Compound 3 gave a limit, no number (the forecaster's own chance of this, stated with the estimate: 75%); the middle value does not contradict the limit.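

No step from compound 2 to compound 3 can be read in this assay, as both compounds give only an assay limit: the limit of > 100000 nM in this assay, at which 3 of the 3 values shown sit.

The compounds shown leave open whether methoxy in place of hydrogen on an aromatic carbon changes the tolerated concentration at all.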